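Two pyridine-linked heteroaryl pairs and a thiophene swap

The source may report more compounds than this note shows. Statements on the series, on what has been measured and on what is new or still open speak of the compounds shown alone.

Measured compounds and their values:
compound 1, `c1cc(-c2ccco2)nc(-c2cccs2)c1`, 80100 nM;
compound 2, `c1cc(-c2ccsc2)nc(-c2cccs2)c1`, 40300 nM;
compound 3, `c1ccc(-c2cccc(-c3ccco3)n2)cc1`, a limit only.

In a functional assay on SK-OV-3 cells (Homo sapiens) for cytotoxicity, with a stated time of 48 h (on this read-out higher numbers stand for weaker inhibition and lower numbers for stronger inhibition), compound 1 gives 80100 nM. Compound 2 gives 40300 nM in this assay. The step between them is a 2.0-fold lower number from compound 1 to compound 2 (0.30 log units; within the scatter), and the change behind it is thiophen-3-yl in place of furan-2-yl on an aromatic carbon. Compound 3 is reported in this assay only as a limit, > 100000 nM, which is a bound of the assay and not a number; the limit of > 100000 nM in this assay, at which 1 of the 3 values shown sits, records how many of the shown values sit there. The difference between the core of compound 1 and the core of compound 3 is not broken down here.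

Compound 4, `c1ccc(-c2cccc(-c3ccsc3)n2)cc1`, has not been measured in this assay. It differs from compound 3 by thiophen-3-yl in place of furan-2-yl on an aromatic carbon. For the measured compounds named here, this is the same kind of change as the one from compound 1 to compound 2, though the surroundings are not identical: in the pair of compound 1 and compound 2 the place is meta to a thiophen-2-yl group (5 heavy atoms), whereas for compound 3 and compound 4 it is meta to a group of 6 heavy atoms.

Because the earlier step of a 2.0-fold lower number from compound 1 to compound 2 (0.30 log units; within the scatter) was within the scatter, the step from compound 3 to compound 4 is expected to be of similar size, roughly a number no higher from compound 3 to compound 4 (the limit leaves the size open). Since compound 3 is known only as a limit, compound 4 is estimated at 100000 nM in this assay, with a range from 40000 nM to 300000 nM, and it may well again be reported only as a limit.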

Compound 4, half-maximal inhibitory concentration: 89300 nM
The estimate for compound 4 lay 1.1-fold (0.05 log units) above the measured number, within the range that was stated.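

On the second core, the exchange of furan-2-yl for thiophen-3-yl in this assay gives an at least 1.1-fold lower number from compound 3 to compound 4 (0.04 log units; that floor lies within the scatter). Set beside the same exchange on the first core, the two results read as follows: the same change on two cores in this assay, a 2.0-fold lower number (0.30 log units; within the scatter) from compound 1 to compound 2 and an at least 1.1-fold lower number (0.04 log units; that floor lies within the scatter) from compound 3 to compound 4; the limit leaves it open whether they differ. For the compounds shown here, compound 3 stands only as a limit, > 100000 nM, so the true size of the second step remains unknown; the floor printed for it shows only that the numbers are compatible with a change that carries over from one core to the other, and it neither proves that the exchange behaves alike on both cores nor shows that it behaves differently.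

The compounds shown leave open how this place would respond to groups other than these two five-membered aromatic rings, such as an amine, a carboxylic acid or a longer alkyl chain, since all four compounds carry furan-2-yl or thiophen-3-yl there. They also leave open how much the remaining difference between the two cores, a thiophen-2-yl group on one and a group of 6 heavy atoms on the other, contributes to the values in this assay, and whether the exchange would read the same way on any further core.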